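A few compounds are considered here, and "the series" means these few. Any claim that something is new, unique, unknown or untested is made for them only; others in the source may bear on it.

Working notes on the series. The shared core is carried by compound 2 `CC(=O)Oc1ccccc1C(=O)O[C@H]1CO[C@H]2[C@@H]1OC[C@H]2OC(=O)C1CC1`, compound 1 `CCC(=O)O[C@@H]1CO[C@H]2[C@@H]1OC[C@@H]2OC(=O)c1ccccc1OC(C)=O` and compound 3 `CC(=O)Oc1ccccc1C(=O)O[C@H]1CO[C@H]2[C@@H]1OC[C@H]2OC(=O)c1ccccc1OC(=O)c1ccccc1`. In an ADME assay on a cell-free system (plasma, Homo sapiens) for metabolic stability, with Plasma (Rattus norvegicus) as the target, read by HPLC, at pH 7.4 (a lower number here means that the compound disappears faster, a higher number that the compound lasts longer), compound 1 gives 0.011 h, compound 2 gives 0.015 h and compound 3 gives 0.0722 h. Compound 2 thus stands second highest of the three numbers, nearest to compound 1 and furthest from compound 3, whose number lies beyond the scatter above it. Among the compounds with values here, the only measured step, a 1.4-fold higher number from compound 1 to compound 2 (0.13 log units; within the scatter), is within the scatter and says little. Compound 4 `CC(=O)Oc1ccccc1C(=O)O[C@H]1CO[C@H]2[C@@H]1OC[C@H]2OC(=O)c1ccc(C#N)cc1` differs from compound 2 as follows: 4-cyanophenyl in place of cyclopropyl on a carbonyl carbon. Within the data shown here, no measured step covers this exact change. Compound 2 and compound 3 also differ on a carbonyl carbon, and there an aromatic ring in place of cyclopropyl goes with the higher number of compound 3; compound 3 carries a different aromatic group, so it is only a loose guide. A moderately higher number is expected for compound 4, a 2.3-fold higher number from compound 2 to compound 4 (0.37 log units; beyond the scatter). The estimate for compound 4 in this assay is 0.035 h, with a range from 0.012 h to 0.1 h.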

Compound 4, half-life: 0.068 h
The estimate for compound 4 lay 1.9-fold (0.29 log units) below the measured number; the range from low to high includes it.
By their numbers in this assay, from the lowest: compounds 1 and 2 (each within the scatter of the next); then compounds 4 and 3 (each within the scatter of the next).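

In this assay, 4-cyanophenyl on this carbonyl carbon gives a 4.5-fold higher number from compound 2 to compound 4 (0.66 log units; beyond the scatter) and a 6.2-fold higher number from compound 1 to compound 4 (0.79 log units; beyond the scatter), so this position now shows steps beyond the scatter, whereas the change from ethyl to cyclopropyl said little. Compound 4 and compound 3 lie within the scatter of each other, so two different aromatic groups at this place give numbers that cannot be separated here, and the earlier loose link between an aromatic ring and a higher number now has a direct step behind it. No measurement at hand bears on what lies behind these steps.

From the compounds shown here alone, whether the aromatic ring alone carries the step or the nitrile on it adds to it stays open, and an unsubstituted phenyl would separate the two. Also open, going by these compounds, is how an amine or a carboxylic acid on that ring, or a longer chain in its place, would read.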